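A few compounds are considered here, and "the series" means these few. Any claim that something is new, unique, unknown or untested is made for them only; others in the source may bear on it.

Measured so far:
- compound 1 `CCN(C)C(=O)/C=C1\CCc2c(F)cc(F)cc21`: in a functional assay on the whole organism with Mus musculus as the target, in the rotarod test (on this read-out lower numbers stand for an effect already at smaller amounts and higher numbers for an effect only at larger amounts of compound), compound 1 gives 73 mg/kg
- compound 2 `CCNC(=O)/C=C1\CCc2ccc(F)cc21`: in this assay compound 2 gives 136 mg/kg

Compound 1 has the lowest of the two numbers, but compound 2 lies close to it, and the two are within the usual scatter of this test, so no order can be read from them. Compound 2 also differs from compound 1 in more than one place, so its value says nothing about any single change.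

The compound still to be measured is compound 3 `O=C(/C=C1\CCc2c(F)cc(F)cc21)NC1CC1`. It differs from compound 1 in one place: cyclopropylamino in place of ethyl(methyl)amino on a carbonyl carbon. Going by the values given here, no measured pair shows this change, so there is no step to lean on; the expectation rests on compound 1 alone. The step is expected to be small, most likely none beyond the scatter, a 1.2-fold higher number from compound 1 to compound 3 (0.09 log units; within the scatter). Compound 3 is therefore estimated at 90 mg/kg, with a range from 40 mg/kg to 200 mg/kg.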

Compound 3, dose for half-maximal effect: 62 mg/kg
Estimate against measurement, compound 3: 1.5-fold (0.16 log units) above; measured number inside the range.
By their numbers in this assay, from the lowest: compounds 3, 1 and 2 (each within the scatter of the next, the first and the last beyond it).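

Going by these compounds alone, this is the first comparison that isolates a single change at this place on the carbonyl carbon. In this assay, cyclopropylamino in place of ethyl(methyl)amino gives a step that is small (a 1.2-fold lower number from compound 1 to compound 3 (0.07 log units; within the scatter)). The swap keeps the count of 4 heavy atoms but brings in a three-membered ring and a hydrogen-bond donor, and the read-out does not move beyond the scatter, so here these two additions leave no measurable mark. No measurement available here explains this result.

As far as these compounds go, the ring and the amide hydrogen enter together, so their separate contributions stay open; cyclopropyl(methyl)amino, which has the ring without that hydrogen, would separate them. From the compounds shown here alone, whether larger changes here are equally silent also stays open, for example a longer chain such as n-hexylamino or a carboxylic acid in place of the amide.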